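This account rests on a few compounds, and the source may have more. Where it says the series, first, only, none or still open, it means among the compounds named here.

The study concerns four compounds built on one shared core, differing only in the length of a saturated chain. Compound 1 `CCCCCOC(=O)CCC(=O)N1CCN(CCCOc2cc3c(Nc4ccc(F)c(Cl)c4)ncnc3cc2OC)CC1` gives 30% in a functional assay on A549 cells (Homo sapiens) for cytotoxicity, read by MTT assay, with a stated time of 24 h, tested at 60 uM; a lower number here means a stronger effect, a higher number a weaker effect of the compound at the concentration tested. Compound 2 `CCCCCCOC(=O)CCC(=O)N1CCN(CCCOc2cc3c(Nc4ccc(F)c(Cl)c4)ncnc3cc2OC)CC1` carries methyl in place of hydrogen on a saturated chain carbon, five bonds along the chain from an oxygen next to a carbonyl group and in this assay compound 2 gives 63.6%, which makes a number 33.6 percentage points higher from compound 1 to compound 2 (beyond the scatter). Compound 3 `CCCCCCCCCCCCCCCOC(=O)CCC(=O)N1CCN(CCCOc2cc3c(Nc4ccc(F)c(Cl)c4)ncnc3cc2OC)CC1` differs from compound 1 by decyl in place of hydrogen on a saturated chain carbon, five bonds along the chain from an oxygen next to a carbonyl group; in this assay compound 3 gives 81.6%, so that a number 51.6 percentage points higher from compound 1 to compound 3 (beyond the scatter) and a number 18 percentage points higher from compound 2 to compound 3 (beyond the scatter). Compound 4 `CCCCCCCCCCCCCCCCOC(=O)CCC(=O)N1CCN(CCCOc2cc3c(Nc4ccc(F)c(Cl)c4)ncnc3cc2OC)CC1` has not yet been measured; relative to compound 3 it carries methyl in place of hydrogen on a saturated chain carbon, ten or more bonds along the chain from an oxygen next to a carbonyl group. Going by the values given here, this is the same kind of change as the one from compound 1 to compound 2, but not at the same place: the added carbon sits further out along the chain than it does in the change from compound 1 to compound 2. Beside a number 33.6 percentage points higher from compound 1 to compound 2 (beyond the scatter), a far smaller step is expected for compound 4, a number 3.4 percentage points higher from compound 3 to compound 4 (within the scatter), because compound 3 already stands at 81.6%. Compound 4 is therefore estimated at 85%, within a range from 72% to 96%.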

Compound 4, a percentage reported as activity, at one concentration (the size of the read-out at that concentration, not a potency): 80%
Beside the measured number, compound 4's estimate is 5 percentage points above it; the measured number falls inside the stated range.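

In this assay the measurement gives a number 1.6 percentage points lower from compound 3 to compound 4 (within the scatter), so the methyl in place of hydrogen that mattered so much in the shorter chain does not carry over to the long chain: the same change on two cores in this assay, a number 33.6 percentage points higher (beyond the scatter) from compound 1 to compound 2 and a number 1.6 percentage points lower (within the scatter) from compound 3 to compound 4, 35.2 percentage points apart, beyond the scatter of two such steps

The longer additions keep their direction, with a number 16.4 percentage points higher from compound 2 to compound 4 (beyond the scatter) and a number 50 percentage points higher from compound 1 to compound 4 (beyond the scatter), but the same change differs in size depending on the chain it starts from: the same change on two cores in this assay, a number 51.6 percentage points higher (beyond the scatter) from compound 1 to compound 3 and a number 16.4 percentage points higher (beyond the scatter) from compound 2 to compound 4, 35.2 percentage points apart, beyond the scatter of two such steps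

This shows that within this series a chain extension cannot be treated as a fixed increment, though it does not show at which chain length the numbers stop rising, nor why the steps differ.

The compounds shown leave open how chains of intermediate length, between those of compound 2 and compound 3, would read, and whether a shorter chain would continue the trend. Also open, going by these compounds, is whether a branched chain, or a chain ending in an amine or a carboxylic acid, would behave like these saturated chains.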